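Shortening the oxime alkyl group: compound 1 to compound 4

The source may hold more compounds than are shown below. What is called first, only, known or untested is meant among the compounds shown, and "the series" means these compounds.

Compound 1 `CC(C)/C(=N\O)c1ccc(Sc2cc(F)cc(C3CCOCC3)c2)cc1` carries an isopropyl on the carbon with a double bond to nitrogen. For the measured compounds named here, in a functional assay (blood) for inhibition, with Homo sapiens as the target (a higher number here means a weaker inhibitor, a lower number a stronger inhibitor), compound 1 gives 300 nM, the highest of the three numbers measured so far. Compound 2 `COC1(c2csc(Sc3ccc4c(c3)OCC/C4=N\OCC#N)c2)CCOCC1`, built on a different core and with a different oxime substituent, gives 60 nM in this assay, a number beyond the scatter below that of compound 1. Compound 3 `C/C(=N/O)c1ccc(COc2cc(F)cc(C3CCOCC3)c2)cc1`, which carries a methyl on the carbon with a double bond to nitrogen and joins its two aromatic parts through an ether rather than through sulfur, gives 40 nM, also beyond the scatter below compound 1. Going by the values given here, no pair of measured compounds differs in a single place, so these comparisons each mix several changes.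

Compound 4 `C/C(=N\O)c1ccc(Sc2cc(F)cc(C3CCOCC3)c2)cc1` differs from compound 1 in one place: methyl in place of isopropyl on a carbon with a double bond to nitrogen. Among the compounds with values here, no measured pair isolates this change. Compound 3 shows that a methyl on that carbon sits in a compound with a low number, but compound 3 also differs in its linker, so its value of 40 nM cannot be assigned to the methyl alone. The step from compound 1 to compound 4 is expected to be a modest decrease, a 2.5-fold lower number from compound 1 to compound 4 (0.40 log units; beyond the scatter), somewhat beyond the scatter. For compound 4 the expected value in this assay is 120 nM, with a range of 40 nM to 350 nM.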

Compound 4, half-maximal inhibitory concentration: 80 nM
Estimate against measurement, compound 4: 1.5-fold (0.18 log units) above; the range from low to high includes it.
By their numbers in this assay, from the lowest: compounds 3, 2 and 4 (each within the scatter of the next); then compound 1.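

In this assay, for the compounds shown here, methyl in place of isopropyl on a carbon with a double bond to nitrogen gives a 3.8-fold lower number from compound 1 to compound 4 (0.57 log units; beyond the scatter), the first step that reads a single change, whereas the earlier comparisons each mixed this position with differences elsewhere. With the rest of compound 1 held fixed, this position alone moves the number beyond the scatter, so the high value of compound 1 is tied at least in part to its isopropyl, and of these two alkyl groups the methyl carries the lower number. Nothing measured here speaks to the reason for this step, which stays unassigned.

The compounds shown leave open how the number follows the group at this carbon between and beyond these two points, for instance with an ethyl, a cyclopropyl or a longer chain. They also leave open whether the same step would hold with the ether link of compound 3 or on the core of compound 2.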